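Cytotoxicity notes: chloro to fluoro on the side chain

A few compounds are considered here, and "the series" means these few. Any claim that something is new, unique, unknown or untested is made for them only; others in the source may bear on it.

Values in an ADME assay on MDCK cells (Canis lupus familiaris) for cytotoxicity, read by cytopathic effect, with a stated time of 48 h; on this read-out lower numbers stand for higher toxicity in this test and higher numbers for lower toxicity in this test:
compound 1 `CCC(=O)Nc1cc(C(=O)Nc2ccc(C)cc2)ccc1OC`: 162 uM
compound 2 `CCC(=O)Nc1cc(C(=O)Nc2nccs2)ccc1OC`: > 655 uM, a limit of the assay and not a number
compound 3 `COc1ccc(C(=O)Nc2ccccc2)cc1NC(=O)C(C)Cl`: 200 uM

Compound 3 and compound 1 give numbers that lie within the usual scatter of each other. Compound 2 reports only a limit, as noted in the limit of > 655 uM in this assay, at which 1 of the 3 values shown sits. Within the data shown here, the sole measured step, an at least 4.0-fold higher number from compound 1 to compound 2 (0.60 log units; beyond the scatter), exchanges the aryl group on an amide-type nitrogen and does not touch the saturated chain. Compound 4 `COc1ccc(C(=O)Nc2ccccc2)cc1NC(=O)C(C)F` differs from compound 3 by fluoro in place of chloro on a saturated chain carbon bound to a carbonyl carbon and a saturated chain carbon. Among the measured compounds shown here, no measured step bears on this exchange, so no step beyond the scatter is expected in this assay: no change at the digits printed from compound 3 to compound 4 (within the scatter). Compound 4 is therefore estimated at 200 uM, expected between 90 uM and 450 uM.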

Compound 4, half-maximal toxic concentration: > 632 uM
Compound 4 was reported as a limit; the forecaster's own chance of this, stated with the estimate: 15%; at least 3.1-fold (0.49 log units) between middle value and limit.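

In this assay, fluoro in place of chloro on this saturated chain carbon gives an at least 3.1-fold higher number from compound 3 to compound 4 (0.49 log units; beyond the scatter), so this position of the side chain can shift the read-out towards lower toxicity in this test. The earlier step changed only the aryl group on an amide-type nitrogen, whereas here the aryl group stays the same and the change lies in the chain alone. Compound 4 gives a limit of the assay and not a number: the limit of > 632 uM in this assay, at which 1 of the 4 values shown sits.

Going by these compounds, the full size of the step stays open. So does the outcome with an amine or a longer chain in place of chloro on this carbon.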